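Compound 3 to compound 4: diethylamino for dimethylamino

The source may report more compounds than this note shows. Statements on the series, on what has been measured and on what is new or still open speak of the compounds shown alone.

Values in a functional assay on HeLa cells (Homo sapiens) for antiproliferative activity, read by MTT assay, with a stated time of 48 h; a lower number here means a stronger inhibitor, a higher number a weaker inhibitor:
Compound 1 `Cn1c(N)c(-c2nc3ccccc3[nH]2)c2nc(C#N)c(C#N)nc21`: > 50000 nM (a limit)
Compound 2 `CCN(CC)CCCCn1c(N)c(-c2nc3ccccc3n2C)c2nc(C#N)c(C#N)nc21`: 1610 nM
Compound 3 `CN(C)CCCCn1c(-c2c(N)n(C)c3nc(C#N)c(C#N)nc23)nc2ccccc21`: 10100 nM

Compound 3 holds the higher of the two values that are not limits, and its gap to compound 2 lies beyond the scatter. Compound 4 `CCN(CC)CCCCn1c(-c2c(N)n(C)c3nc(C#N)c(C#N)nc23)nc2ccccc21` carries diethylamino in place of dimethylamino on a saturated chain carbon, four bonds along the chain from an aromatic nitrogen. Within the data shown here, the only measured step, an at least 4.9-fold lower number from compound 1 to compound 3 (0.69 log units; beyond the scatter), adds the whole chain rather than changing its end, so it bears only indirectly. Compound 2 also ends in diethylamino and gives 1610 nM, which hints at a lower number in this assay, though it differs elsewhere. The expected step is a 1.7-fold lower number from compound 3 to compound 4 (0.23 log units; within the scatter), possibly within the scatter. For compound 4 the estimated value is 6000 nM, with an expected range from 2000 nM to 15000 nM.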

Compound 4, half-maximal inhibitory concentration: 11800 nM
For compound 4 the middle estimate is 2.0-fold (0.29 log units) below the measured one, within the range that was stated.
By their numbers in this assay, from the lowest: compound 2; then compounds 3 and 4 (each within the scatter of the next). At a limit, above all of these: compound 1.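

In this assay, diethylamino and dimethylamino at the end of the butyl chain cannot be told apart, with a 1.2-fold higher number from compound 3 to compound 4 (0.07 log units; within the scatter). The chain with the diethylamino end also separates from the hydrogen on the aromatic nitrogen, with an at least 4.2-fold lower number from compound 1 to compound 4 (0.62 log units; beyond the scatter). That step is only a bound, since compound 1 stands at a limit and not at a number: the limit of > 50000 nM in this assay, at which 1 of the 4 values shown sits.

The compounds shown leave open how a ring amine such as piperidine or morpholine at the chain end would read. On these data alone, a shorter propyl or longer hexyl chain also remains open.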